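A few compounds are considered here, and "the series" means these few. Any claim that something is new, unique, unknown or untested is made for them only; others in the source may bear on it.

Measured so far:
compound 1 `Cn1ccc2cc(-c3cc4nccc(-c5ccc(F)cc5)n4n3)ccc21` — 2160 nM
compound 2 `COc1cc(-c2ccnc3cc(-c4cccc(C#N)c4)nn23)cc(OC)c1OC` — limit only

In a functional assay on HCT-116 cells (Homo sapiens) for inhibition, read by CCK-8 assay, with a stated time of 48 h (a lower number here means a stronger inhibitor, a higher number a weaker inhibitor), compound 1 gives 2160 nM. For compound 2 the result is a limit, not a number: > 10000 nM, which is the limit of > 10000 nM in this assay, at which 1 of the 2 values shown sits. Compound 3 `COc1cc(-c2ccnc3cc(-c4ccc5cnn(C)c5c4)nn23)cc(OC)c1OC` is not yet measured. It differs from compound 2 in one place: 1-methyl-1H-indazol-6-yl in place of 3-cyanophenyl on an aromatic carbon. Within the data shown here, with no measured step of this kind, the expectation rests on compound 1, whose 2160 nM shows that a methylated bicyclic group at this place can give a numbered value. For compound 3 a move toward stronger inhibition beyond the scatter is expected, an at least 2.0-fold lower number from compound 2 to compound 3 (0.30 log units; that floor lies within the scatter), with the estimate 5000 nM ranging from 1500 nM to 20000 nM.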

Compound 3, half-maximal inhibitory concentration: 2440 nM
Estimate against measurement, compound 3: 2.0-fold (0.31 log units) above; low and high end bracket the measured number.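

In this assay, the aromatic carbon next to the ring nitrogen now has a readable step: 1-methyl-1H-indazol-6-yl in place of 3-cyanophenyl gives an at least 4.0-fold lower number from compound 2 to compound 3 (0.61 log units; beyond the scatter). With the rest of the core held fixed, the group at this place alone therefore moves the read-out beyond the scatter. The true size of the step remains unknown, since compound 2 stands at a limit: the limit of > 10000 nM in this assay, at which 1 of the 3 values shown sits.

As far as these compounds go, whether the second ring, its ring nitrogens or the methyl group carries the step stays open. Also open, from the compounds shown here alone, is how an amine or a carboxylic acid in place of the nitrile would read.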